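Two chlorines for one on a diaryl urea

This account rests on a few compounds, and the source may have more. Where it says the series, first, only, none or still open, it means among the compounds named here.

Measured compounds in an assay on isolated protein for inhibition of Polyunsaturated fatty acid 5-lipoxygenase (Homo sapiens), read by HPLC, with a stated time of 10 min; on this read-out lower numbers stand for stronger inhibition and higher numbers for weaker inhibition:
compound 1 `Cc1cc(NC(=O)Nc2cc(Cl)cc(Cl)c2)ccc1OCc1nc2ccccc2s1` gives 720 nM
compound 2 `O=C(Nc1ccc(OCc2nc3ccccc3s2)cc1)Nc1ccc(Cl)c(Cl)c1` gives 570 nM
compound 3 `O=C(Nc1ccc(Cl)cc1)Nc1ccc(OCc2nc3ccccc3s2)cc1` gives 1010 nM

The three numbers lie within the usual scatter of one another, so compound 3 cannot be set apart from compound 1 or compound 2 on this assay; its gap to compound 1 and its gap to compound 2 are both within the scatter.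

Compound 4 `O=C(Nc1ccc(OCc2nc3ccccc3s2)cc1)Nc1cc(Cl)cc(Cl)c1` differs from compound 3 in one place: 3,5-dichlorophenyl in place of 4-chlorophenyl on an amide-type nitrogen. Among the measured compounds shown here, only one measured step touches a chlorine on that ring, and it is a 1.8-fold higher number from compound 2 to compound 3 (0.25 log units; within the scatter), a change that stays within the scatter. For the measured compounds named here, no step pairs a 3,5-dichlorophenyl against a 4-chlorophenyl directly. Compound 1 carries the same 3,5-dichlorophenyl, though on a core that also bears a methyl group, and compound 1 gives 720 nM, a number that sits within the scatter of compound 3. Going by the values given here, the single chlorine step gave no movement beyond the scatter, so nothing here points to a step beyond the scatter from compound 3 to compound 4. Compound 4 is therefore expected to give 720 nM, with a range from 350 nM to 1500 nM. This estimate means a step of a 1.4-fold lower number from compound 3 to compound 4 (0.15 log units; within the scatter), expected to stay within the scatter.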

Compound 4, half-maximal inhibitory concentration: 90 nM
Compound 4: the middle estimate sits 8.0-fold (0.90 log units) above what was measured, outside the stated range (below it).
By their numbers in this assay, from the lowest: compound 4; then compounds 2, 1 and 3 (each within the scatter of the next).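

In this assay the ring on the amide-type nitrogen proves more sensitive than the earlier chlorine step suggested: that step of a 1.8-fold higher number from compound 2 to compound 3 (0.25 log units; within the scatter) stayed within the scatter, whereas 3,5-dichlorophenyl in place of 4-chlorophenyl gives an 11-fold lower number from compound 3 to compound 4 (1.05 log units; beyond the scatter) and lies beyond it. Both dichlorophenyl rings carry two chlorines, yet 3,5-dichlorophenyl in place of 3,4-dichlorophenyl gives a 6.3-fold lower number from compound 2 to compound 4 (0.80 log units; beyond the scatter) and so, among these compounds, where the chlorines sit counts and not only how many there are. The 3,5-dichlorophenyl group also does not give the low number on its own, for with that group kept in both compounds, dropping the methyl group gives an 8.0-fold lower number from compound 1 to compound 4 (0.90 log units; beyond the scatter) as a further step beyond the scatter.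

Nothing shown here gives a measured reason for either effect, so why the chlorine pattern and the methyl group matter stays unexplained. As far as these compounds go, it also remains open whether bromine or methoxy in place of the two chlorines would hold the low number, and whether an ethyl or a fluorine in place of the methyl would cost as much as the methyl does.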